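Three Methoxy Groups Added to a Weak Compound

A few compounds are considered here, and "the series" means these few. Any claim that something is new, unique, unknown or untested is made for them only; others in the source may bear on it.

The series shares one core, seen in compound 1 `O=C(/C=C\Nc1ccc(F)cc1)c1cn(-c2ccccc2)nc1-c1ccccc1`, which carries a fluoro group on its outer ring. In a functional assay on U-87MG ATCC cells (Homo sapiens) for antiproliferative activity, read by MTT assay, with a stated time of 48 h (a lower number here means a stronger inhibitor, a higher number a weaker inhibitor), compound 1 gives 10200 nM. Compound 2 `O=C(/C=C\Nc1ccc(C(F)(F)F)cc1)c1cn(-c2ccccc2)nc1-c1ccccc1` carries trifluoromethyl in place of fluoro on an aromatic carbon. In this assay compound 2 reaches only a limit of the assay, > 50000 nM, so no number is known for it. Compound 3 `COc1ccc(N/C=C\C(=O)c2cn(-c3ccccc3)nc2-c2ccccc2)cc1` carries methoxy in place of fluoro on an aromatic carbon. For compound 3 this assay also reports only a limit, > 50000 nM. Both changes weaken the compound: an at least 4.9-fold higher number from compound 1 to compound 2 (0.69 log units; beyond the scatter) and an at least 4.9-fold higher number from compound 1 to compound 3 (0.69 log units; beyond the scatter). The remaining step cannot be read: a step that the two limits leave unreadable from compound 2 to compound 3. Compound 2 therefore stands at the limit, weaker than compound 1 by at least a modest step, and the limit of > 50000 nM in this assay, at which 2 of the 3 values shown sit, marks where two of the three values sit.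

Compound 4 `COc1cc(-c2nn(-c3ccccc3)cc2C(=O)/C=C\Nc2ccc(C(F)(F)F)cc2)cc(OC)c1OC` differs from compound 2 in a different place: 3,4,5-trimethoxyphenyl in place of phenyl on an aromatic carbon. Among the compounds with values here, none of the measured steps touches this phenyl, so they give no direct guide; they show only that compound 2 starts where any further loss could not be read. With nothing to pull the number either way, compound 4 is expected to stay near the same limit, with an estimated 60000 nM (range 10000 nM to 300000 nM), meaning an expected step that the limit leaves unreadable from compound 2 to compound 4.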

Compound 4, half-maximal inhibitory concentration: > 50000 nM
Compound 4: a limit, no number (the forecaster's own chance of this, stated with the estimate: 70%); the middle value is on the limit's open side.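

In this assay compound 4 gives > 50000 nM, which is a limit and not a number. No step can be read from compound 2 to compound 4, because both compounds stop at a limit: the limit of > 50000 nM in this assay, at which 3 of the 4 values shown sit. The compounds shown leave open whether 3,4,5-trimethoxyphenyl in place of phenyl would strengthen or weaken a compound with a readable number, such as compound 1.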